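This account rests on a few compounds, and the source may have more. Where it says the series, first, only, none or still open, it means among the compounds named here.

Measured in a functional assay on HeLa cells (Homo sapiens) for cytotoxicity, read by MTT assay, with a stated time of 48 h (a lower number here means a stronger inhibitor, a higher number a weaker inhibitor), so far:
- compound 1 `COc1cc(/C=C/C(=O)C2=C(/C=C/c3ccc(O)c(OC)c3)NC(=O)NC2c2ccccc2)ccc1O` gives 100000 nM
- compound 2 `COc1cc(/C=C/C(=O)C2=C(/C=C/c3ccc(O)c(OC)c3)NC(=O)NC2c2ccc(C)cc2)ccc1O` gives 100000 nM
- compound 3 `COc1cc(/C=C/C(=O)C2=C(/C=C/c3ccc(O)c(OC)c3)NC(=O)NC2c2ccccc2O)ccc1O` gives 50000 nM

Compound 3 sits within the scatter of both others, its steps being a 2.0-fold lower number from compound 1 to compound 3 (0.30 log units; within the scatter) and a 2.0-fold lower number from compound 2 to compound 3 (0.30 log units; within the scatter) in that comparison. Compound 4 `COc1cc(/C=C/C(=O)C2=C(/C=C/c3ccc(O)c(OC)c3)NC(=O)NC2c2ccc(O)cc2)ccc1O` is still unmeasured and differs from compound 3 thus 4-hydroxyphenyl in place of 2-hydroxyphenyl on a saturated ring carbon with 4-hydroxyphenyl in place of 2-hydroxyphenyl on a saturated ring carbon. Those two steps bear on it, along with no change at the digits printed from compound 1 to compound 2 (within the scatter) for methyl in place of hydrogen, and all stay within the scatter. None compares the two hydroxyphenyl groups directly, so no step beyond the scatter is expected in this assay for this pair. The expected change is a 1.4-fold higher number from compound 3 to compound 4 (0.15 log units; within the scatter) overall. Compound 4 is estimated at 70000 nM with a range from 30000 nM to 150000 nM as the expectation.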

Compound 4, half-maximal inhibitory concentration: 25000 nM
Compound 4: the middle estimate sits 2.8-fold (0.45 log units) above what was measured; measured number outside the range, below it.
By their numbers in this assay, from the lowest: compounds 4, 3, 1 and 2 (each within the scatter of the next, the first and the last beyond it).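

In this assay, 4-hydroxyphenyl on the saturated ring carbon brings the first steps beyond the scatter among these compounds, with a 4.0-fold lower number from compound 1 to compound 4 (0.60 log units; beyond the scatter) for hydroxy in place of hydrogen and a 4.0-fold lower number from compound 2 to compound 4 (0.60 log units; beyond the scatter) for hydroxy in place of methyl, both modest in size. Exchanging 2-hydroxyphenyl for 4-hydroxyphenyl gives a 2.0-fold lower number from compound 3 to compound 4 (0.30 log units; within the scatter) and so does not separate the two hydroxyphenyl groups. Nothing available explains these steps. On these data alone, whether an amine or a carboxylic acid in place of the hydroxy on this phenyl ring would keep the step remains open.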